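A chloro group on a compound at the limit

The compounds below may be only part of what the source reports. "The series", "measured", "known", "first", "only" and "open" are said of these compounds alone.

Measured in a functional assay on MCF7 cells (Homo sapiens) for cytotoxicity, read by MTT assay, with a stated time of 24 h; on this read-out higher numbers stand for weaker inhibition and lower numbers for stronger inhibition:
compound 1 `C=CCn1c(=O)c(C=O)cc2ccccc21`: > 100000 nM, a limit
compound 2 `O=Cc1cc2ccccc2n(Cc2ccccc2)c1=O`: 31900 nM
compound 3 `C#CCn1c(=O)c(C=O)cc2ccccc21`: > 100000 nM, a limit

Compound 3 gives no number, only the limit > 100000 nM. It shares that position with compound 1, as the set holds (the limit of > 100000 nM in this assay, at which 2 of the 3 values shown sit). Only compound 2 gives a true number.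

Compound 4 `C#CCn1c(=O)c(C=O)cc2cc(Cl)ccc21` keeps the ethynyl group of compound 3 and changes the shared core in one place: chloro in place of hydrogen on an aromatic carbon. For the measured compounds named here, no measured step tests a chloro group. All three measured steps swap the group on the saturated chain carbon bound to the aromatic nitrogen, so they bear on this change only indirectly. One is an at least 3.1-fold lower number from compound 1 to compound 2 (0.49 log units; beyond the scatter), another is an at least 3.1-fold higher number from compound 2 to compound 3 (0.49 log units; beyond the scatter), and the third is a step that the two limits leave unreadable from compound 1 to compound 3. They show that numbers below the limit are reachable in this small set, but they do not size a chloro step. A modest move towards a lower number is therefore expected in this assay, and compound 4 may well give only a limit again. The expected step is an at least 1.6-fold lower number from compound 3 to compound 4 (0.22 log units; that floor lies within the scatter). For compound 4 the estimate is 60000 nM, with an expected range from 20000 nM to 100000 nM.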

Compound 4, half-maximal inhibitory concentration: > 100000 nM
Compound 4: only a limit was reported; the forecaster's own chance of this, stated with the estimate: 45%; at least 1.6-fold (0.22 log units) between middle value and limit.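

In this assay compound 4 gives > 100000 nM, which is a limit and not a number. Compound 3 also gives only a limit, so the step from compound 3 to compound 4 cannot be read, and compound 4 joins the compounds held at this limit: the limit of > 100000 nM in this assay, at which 3 of the 4 values shown sit.

The compounds shown leave open what a chloro group does to a compound that gives a true number.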